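The source may report more compounds than this note shows. Statements on the series, on what has been measured and on what is new or still open speak of the compounds shown alone.

Of the compounds shown here, three of one series have been tested in a functional assay on HeLa cells (Homo sapiens) for antiproliferative activity, read by sulforhodamine B assay, with a stated time of 48 h; on this read-out lower numbers stand for stronger inhibition of growth and higher numbers for weaker inhibition of growth. Compound 1, with the structure `O=C(NCc1cn(Cc2ccc(Cl)cc2)nn1)c1cn(-c2ccccc2)nc1-c1ccccc1`, gives 600 nM. Compound 2, with the structure `O=C(NCc1cn(Cc2ccc(C(F)(F)F)cc2)nn1)c1cn(-c2ccccc2)nc1-c1ccccc1`, gives 1600 nM. Compound 3, with the structure `COc1ccc(-c2nn(-c3ccccc3)cc2C(=O)NCc2cn(Cc3ccc(Cl)cc3)nn2)cc1`, gives 6400 nM.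

Compound 2 differs from compound 1 by one change, (trifluoromethyl in place of chloro on an aromatic carbon), and that change brought a 2.7-fold higher number from compound 1 to compound 2 (0.43 log units; beyond the scatter). Among the measured compounds shown here, compound 3 differs from compound 1 in a different way, (methoxy in place of hydrogen on an aromatic carbon), and that change brought an 11-fold higher number from compound 1 to compound 3 (1.03 log units; beyond the scatter), so compound 3 has the highest number of the three compounds measured so far.

Compound 4, with the structure `COc1ccc(-c2nn(-c3ccccc3)cc2C(=O)NCc2cn(Cc3ccc(C(F)(F)F)cc3)nn2)cc1`, has not yet been measured in this assay. It differs from compound 3 by trifluoromethyl in place of chloro on an aromatic carbon, which is the same change that turns compound 1 into compound 2, made here on the core of compound 3 rather than the core of compound 1. How the two cores differ is told by methoxy in place of hydrogen on an aromatic carbon. Since the place of the change reads the same in both cases, the step from compound 3 to compound 4 is expected to resemble the step seen from compound 1 to compound 2: compound 4 is expected to show a 2.5-fold higher number from compound 3 to compound 4 (0.40 log units; beyond the scatter) in this assay, which rests on a 2.7-fold higher number from compound 1 to compound 2 (0.43 log units; beyond the scatter). On that basis compound 4 is estimated at 16000 nM, with a likely range from 6000 nM to 45000 nM; a single prior example is a thin footing, so the range is kept wide.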

Compound 4, concentration for 50% growth inhibition: 6200 nM
For compound 4 the middle estimate is 2.6-fold (0.41 log units) above the measured one, within the range that was stated.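

In this assay, trifluoromethyl in place of chloro on the core of compound 3 gives a 1.0-fold lower number from compound 3 to compound 4 (0.01 log units; within the scatter), so the rise in the number seen on the core of compound 1 does not carry over to this second core: the same change on two cores in this assay, a 2.7-fold higher number (0.43 log units; beyond the scatter) from compound 1 to compound 2 and a 1.0-fold lower number (0.01 log units; within the scatter) from compound 3 to compound 4, 2.8-fold (0.44 log units) apart, beyond the scatter of two such steps. Read the other way, methoxy in place of hydrogen still raises the number when trifluoromethyl is present, with a 3.9-fold higher number from compound 2 to compound 4 (0.59 log units; beyond the scatter), so the direction of that change holds across the pair while its size does not: the same change on two cores in this assay, an 11-fold higher number (1.03 log units; beyond the scatter) from compound 1 to compound 3 and a 3.9-fold higher number (0.59 log units; beyond the scatter) from compound 2 to compound 4, 2.8-fold (0.44 log units) apart, beyond the scatter of two such steps. These two gaps come from the same four compounds and describe one pattern: in this small set the two changes do not simply add up, so a step measured on one core is an unsafe guide to the step on another, but the data do not show why, or whether this would hold on any further core.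

Going by these compounds, whether a nitrile or a methyl group in place of chloro would behave the same way on both cores stays open, as does the outcome with a hydroxyl or a dimethylamino group in place of methoxy. On these data alone, whether the pattern extends to cell lines other than those in this assay also stays open.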